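The source may report more compounds than this note shows. Statements on the series, on what has been measured and on what is new or still open speak of the compounds shown alone.

Working notes on the series, read in a functional assay on HCT-116 cells (Homo sapiens) for inhibition; a higher number here means a weaker inhibitor of growth, a lower number a stronger inhibitor of growth. Within the data shown here, compound 1 (`Cc1n[nH]c(-c2ccc(O)c(Cl)c2)c1-c1ccc2c(c1)OCCO2`) has no result reported here, so compound 2 (`Cc1n[nH]c(-c2cc(Cl)c(O)cc2O)c1-c1ccc(OCCCC#N)cc1`) supplies the only number available: in this assay, compound 2 gives 3600 nM. With no second value, this number cannot yet be ranked within the series.

Compound 3 (`Cc1n[nH]c(-c2cc(Cl)c(O)cc2O)c1-c1ccccc1`) has not been measured. It keeps the core of compound 2 but has hydrogen in place of 3-cyanopropoxy on an aromatic carbon, para to a large group: hydrogen in place of 3-cyanopropoxy on an aromatic carbon.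

Among the measured compounds shown here, no step between measured compounds shows what this change does in this assay, so its size has no direct calibration. The expectation rests on compound 2 at 3600 nM alone. With nothing to indicate a large move in either direction, no shift beyond the usual scatter is expected, although the uncertainty is wide. The expected change is a 1.1-fold higher number from compound 2 to compound 3 (0.05 log units; within the scatter). For compound 3 the estimated value is 4000 nM, with an expected range of 1400 nM to 12000 nM.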

Compound 3, concentration for 50% growth inhibition: 6400 nM
Compound 3: middle estimate off by 1.6-fold (0.20 log units), on the low side; the measured number falls inside the stated range.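

In this assay, the series now has its first direct reading at this position: hydrogen in place of 3-cyanopropoxy on an aromatic carbon, para to a large group, gives a 1.8-fold higher number from compound 2 to compound 3 (0.25 log units; within the scatter) and so stays inside what repeated measurements can resolve. Within this single pair, the whole 3-cyanopropoxy chain, with its nitrile, can therefore be exchanged for hydrogen without a change that can be told from scatter, and the growth inhibition of compound 2 cannot be assigned to that chain. No measurement at hand bears on the reason for this result, and none is offered here.

Still open, from the compounds shown here alone, is whether any other group on this aromatic carbon would carry the number beyond the scatter in either direction, for example a methoxy group, a primary amine, a carboxylic acid or a longer chain ending in a nitrile. One pair also says nothing on whether the same exchange would read alike with other groups on the rest of the shared core.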